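Phenyl in place of nitro in compound 2

A few compounds are considered here, and "the series" means these few. Any claim that something is new, unique, unknown or untested is made for them only; others in the source may bear on it.

compound 1 `CC(C)(C)OC(=O)NCc1ccc(NC(=O)CCc2cccc3c2B(O)OC3)cc1` | 4800 nM
compound 2 `O=C(CCc1cccc2c1B(O)OC2)Nc1ccc([N+](=O)[O-])cc1` | > 100000 nM (a limit)

In an ADME assay on WI-38 cells (Homo sapiens) for cytotoxicity, read by MTT assay, with a stated time of 72 h (a lower number here means a stronger inhibitor, a higher number a weaker inhibitor), compound 2 gives > 100000 nM and this is a limit of the assay, not a number. Compound 3 `O=C(CCc1cccc2c1B(O)OC2)Nc1ccc(-c2ccccc2)cc1` differs from it by phenyl in place of nitro on an aromatic carbon and so carries phenyl in place of nitro on an aromatic carbon. Within the data shown here, the one measured step at this place is an at least 20-fold higher number from compound 1 to compound 2 (1.31 log units; beyond the scatter) and it is large and beyond the scatter. That step shows that the read-out can shift strongly with the group at this carbon, although it rests on two compounds only. With nitro leaving again, a move towards a lower number is expected, and compound 1 at 4800 nM shows that a measurable number is possible without nitro. The expected move is an at least 3.3-fold lower number from compound 2 to compound 3 (0.52 log units; beyond the scatter) and it is uncertain in size. Compound 3 is estimated at 30000 nM (expected range 8000 nM to 100000 nM).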

Compound 3, half-maximal inhibitory concentration: 32000 nM
For compound 3 the middle estimate is 1.1-fold (0.03 log units) below the measured one, within the range that was stated.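

In this assay, phenyl in place of nitro gives an at least 3.1-fold lower number from compound 2 to compound 3 (0.49 log units; beyond the scatter), so a group of carbon only with an aromatic ring also gives a measurable number at this aromatic carbon. Phenyl does not match the ((tert-butoxycarbonyl)amino)methyl group, however: the comparison gives a 6.7-fold higher number from compound 1 to compound 3 (0.82 log units; beyond the scatter), which places the phenyl compound between the other two and shows that removing nitro does not by itself restore the level of compound 1. The value of compound 2 is a limit and not a number: the limit of > 100000 nM in this assay, at which 1 of the 3 values shown sits.

Going by these compounds, whether an aminomethyl group or a carboxylic acid at this carbon would lie nearer compound 1 or compound 3 stays open. On these data alone, all three compounds share one core, so whether these steps hold on any other core also remains unknown.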